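A few compounds are considered here, and "the series" means these few. Any claim that something is new, unique, unknown or untested is made for them only; others in the source may bear on it.

- Compound 1 `O=C(O)CCCCC(CCSC(=O)c1ccccc1)SC(=O)c1ccccc1`: "not active" (no number reported)
- Compound 2 `O=C(CCCCC(S)CCS)Nc1cccc(C(F)(F)F)c1`: 1.66%
- Compound 3 `O=C(CCCCC(CCSC(=O)c1ccccc1)SC(=O)c1ccccc1)Nc1ccccc1`: "not active" (no number reported)
- Compound 4 `O=C(CCCCC(CCSC(=O)c1ccccc1)SC(=O)c1ccccc1)Nc1ccccc1Cl`: not yet measured

All of these compounds are judged by a functional assay on Bel-7402 cells (Homo sapiens) for inhibition, read by MTT assay, with a stated time of 24 h, tested at 1 ug/mL; on this read-out lower numbers stand for less inhibition of growth and higher numbers for more inhibition of growth at the one concentration tested. On this test compound 3 gives "not active" (no number reported), so it has no single number to stand on. Among the compounds with values here, compound 1 shares that result, while compound 2 is the only one with a number, at 1.66%.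

Compound 4 is built from compound 3 by one small change: chloro in place of hydrogen on an aromatic carbon. Chloro takes the place of hydrogen on an aromatic carbon, ortho to a large group, turning phenyl into 2-chlorophenyl. Within the data shown here, no pair of measured compounds shows what such a change does, so there is no direct guide to its size. The expectation therefore rests on compound 3, which gives "not active" (no number reported), and no step beyond the scatter is foreseen, in either direction. For compound 4 the estimated growth inhibition is 4%, with an expected range from 0% to 18%.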

Compound 4, percent growth inhibition at one concentration: 7.37%
The estimate for compound 4 lay 3.4 percentage points below the measured number; low and high end bracket the measured number.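

In this assay compound 3 gives "not active" (no number reported) and compound 4 gives 7.37% so no step can be read between them. As far as these compounds go, what turning phenyl into 2-chlorophenyl does to growth inhibition stays open. Nothing shown here offers an explanation for the result.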